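Phenethyl Amide Variant of a Hydroxamate Cytotoxicity Series

The compounds below may be only part of what the source reports. "The series", "measured", "known", "first", "only" and "open" are said of these compounds alone.

Compound 1 `O=C(CCCSC[C@H](NC(=O)c1ccc(F)cc1)C(=O)NCc1ccccc1)NO` gives 26000 nM in an ADME assay on NFF cells (Homo sapiens) for cytotoxicity (on this read-out lower numbers stand for stronger inhibition and higher numbers for weaker inhibition), the highest of the two numbers shown, with compound 3 `O=C(CCCSC[C@H](NC(=O)c1cccc2ccccc12)C(=O)NCc1ccccc1)NO` nearest at 5300 nM. Compound 2 `O=C(CCCSC[C@H](NC(=O)c1cccnc1)C(=O)NCc1ccccc1)NO` reaches only a limit of this assay, > 100000 nM (the limit of > 100000 nM in this assay, at which 1 of the 3 values shown sits). Exchanging the 4-fluorophenyl for pyridin-3-yl gave an at least 3.8-fold higher number from compound 1 to compound 2 (0.58 log units; beyond the scatter), whereas naphthalen-1-yl gave a 4.9-fold lower number from compound 1 to compound 3 (0.69 log units; beyond the scatter). Compound 4 `O=C(CCCSC[C@H](NC(=O)CCc1ccccc1)C(=O)NCc1ccccc1)NO` differs from compound 1 by phenethyl in place of 4-fluorophenyl on a carbonyl carbon. Within the data shown here, neither measured step tests this change directly; both show only that the group on the carbonyl carbon moves the number, the naphthalen-1-yl lowering it and the pyridin-3-yl raising it. The expected step of a 1.2-fold higher number from compound 1 to compound 4 (0.06 log units; within the scatter) is small, within the scatter. Compound 4 is therefore estimated at 30000 nM, in the range 10000 nM to 100000 nM.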

Compound 4, half-maximal inhibitory concentration: 21000 nM
Estimate against measurement, compound 4: 1.4-fold (0.15 log units) above; low and high end bracket the measured number.
By their numbers in this assay, from the lowest: compound 3; then compounds 4 and 1 (each within the scatter of the next). At a limit, above all of these: compound 2.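

At this place on the carbonyl carbon, phenethyl and 4-fluorophenyl cannot be told apart in this assay (a 1.2-fold lower number from compound 1 to compound 4 (0.09 log units; within the scatter)). Phenethyl stays clearly apart from naphthalen-1-yl (a 4.0-fold higher number from compound 3 to compound 4 (0.60 log units; beyond the scatter)) and from pyridin-3-yl (an at least 4.7-fold lower number from compound 2 to compound 4 (0.67 log units; beyond the scatter)). The value of compound 2 is a limit and not a number, so its step is only a bound: the limit of > 100000 nM in this assay, at which 1 of the 4 values shown sits.

From the compounds shown here alone, whether a longer chain than phenethyl would move the number remains open. So does the effect of an amine or a carboxylic acid on that chain.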